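Swapping a Benzyl Urea for a Pyridyl Amide

The source may hold more compounds than are shown below. What is called first, only, known or untested is meant among the compounds shown, and "the series" means these compounds.

Compound 1 `CC(=O)N1CCN(C(=O)N2Cc3c(NC(=O)c4ccc(F)cc4)n[nH]c3C2(C)C)CC1`: > 10000 nM
Compound 2 `CN1CCC(C(=O)N2Cc3c(NC(=O)NCc4ccccc4)n[nH]c3C2(C)C)CC1`: 2680 nM

Both compounds share a core and were tested in a functional assay on A2780 cells (Homo sapiens) for antiproliferative activity, read by fluorescence, with a stated time of 72 h; a lower number here means a stronger inhibitor, a higher number a weaker inhibitor. For compound 1 the result > 10000 nM is a limit of the assay, not a number. Going by the values given here, compound 2 gives 2680 nM in this assay, the only number among the two values. The value of compound 1 sits at the limit (the limit of > 10000 nM in this assay, at which 1 of the 2 values shown sits). Among the compounds with values here, since compounds 1 and 2 differ in more than one place, the values show only that compound 2 can be measured and compound 1 cannot.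

Compound 3, `CN1CCC(C(=O)N2Cc3c(NC(=O)c4ccncc4)n[nH]c3C2(C)C)CC1`, keeps everything of compound 2 except one group: pyridin-4-yl in place of benzylamino on a carbonyl carbon. Compound 1, which likewise carries an aromatic ring directly on that carbonyl carbon, stands at the limit (the limit of > 10000 nM in this assay, at which 1 of the 2 values shown sits), though it differs elsewhere too. The step of a 2.2-fold higher number from compound 2 to compound 3 (0.35 log units; beyond the scatter) is expected to run toward weaker inhibition, beyond the scatter. Compound 3 is estimated at 6000 nM, with a range from 1500 nM to 20000 nM.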

Compound 3, half-maximal inhibitory concentration: 500 nM
The estimate for compound 3 lay 12-fold (1.08 log units) above the measured number; measured number outside the range, below it.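

In this assay, pyridin-4-yl in place of benzylamino on a carbonyl carbon gives a 5.4-fold lower number from compound 2 to compound 3 (0.73 log units; beyond the scatter), so this place on the shared core responds clearly to the group it carries. The change removes the hydrogen-bond donor counted in benzylamino and sets an aromatic ring directly on the carbonyl carbon, and compound 3 is still the stronger inhibitor of this pair. Compound 1 also has an aromatic ring directly on that carbon, but it differs elsewhere too and its result is only a limit: the limit of > 10000 nM in this assay, at which 1 of the 3 values shown sits.

This single step changes the ring, the link to the carbonyl and the donor count together, so it cannot show which of these matters. A plain phenyl ring or a pyridin-3-yl group on the same carbonyl carbon would help to separate them.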